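Swapping the acid-bearing ring in a glutamate receptor modulator series

The source may report more compounds than this note shows. Statements on the series, on what has been measured and on what is new or still open speak of the compounds shown alone.

Compound 1 `Cc1c(OCCCCOc2cccc(C(=O)O)c2)ccc(C(=O)CC2CCCC2)c1O`: 451 nM
Compound 2 `COC(=O)c1ccc(OCCCCOc2ccc(C(=O)CC(C)C)c(O)c2C)cc1`: "not determined" (no result reported)
Compound 3 `Cc1c(OCCCCOc2ccc(C(=O)O)cc2Cl)ccc(C(=O)CC(C)C)c1O`: 96 nM

In an assay on HEK293 cells for positive allosteric modulation of metabotropic glutamate receptor 2 (Rattus norvegicus), read by thallium flux, with a stated time of 2.5 min (on this read-out lower numbers stand for an effect already at smaller amounts and higher numbers for an effect only at larger amounts of compound), compound 3 gives 96 nM, the lowest of the two numbers shown; compound 1 gives 451 nM, a gap beyond the usual scatter, and for compound 2 no number was obtained. Compound 4 `Cc1c(OCCCCOc2cccc(C(=O)O)c2)ccc(C(=O)CC(C)C)c1O` has not yet been measured. It differs from compound 3 in one place: 3-carboxyphenyl in place of 4-carboxy-2-chlorophenyl on an oxygen on a saturated carbon. Compound 1 already carries the 3-carboxyphenyl group that enters here, though its chain on the ketone is different. For the measured compounds named here, with no measured pair isolating this exact change, the expected step is modest and toward higher numbers, estimated as a 2.9-fold higher number from compound 3 to compound 4 (0.46 log units; beyond the scatter). Compound 4 is therefore expected to give about 280 nM in this assay, within a range of 110 nM to 750 nM.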

Compound 4, half-maximal effective concentration: 222 nM
Beside the measured number, compound 4's estimate is 1.3-fold (0.10 log units) above it; the range from low to high includes it.
By their numbers in this assay, from the lowest: compound 3; then compound 4; then compound 1.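

Within this assay, the swap of 4-carboxy-2-chlorophenyl for 3-carboxyphenyl on the oxygen, with the isopropyl ketone chain held constant, gives a 2.3-fold higher number from compound 3 to compound 4 (0.36 log units; beyond the scatter) and so shows that this ring alone shifts the number. With 3-carboxyphenyl held constant, isopropyl in place of cyclopentyl gives a 2.0-fold lower number from compound 1 to compound 4 (0.31 log units; beyond the scatter) and shows that the ketone chain matters too. No evidence here explains either step.

The ring swap changes the chlorine and the acid's place together, so their shares stay unresolved. On these data alone, how a tetrazole in place of the carboxylic acid would behave also remains open.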